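Swapping a benzodioxin for a bromophenyl on the amine arm

The compounds below may be only part of what the source reports. "The series", "measured", "known", "first", "only" and "open" are said of these compounds alone.

Two sulfonamides built on the same core have been measured so far. Compound 1 `O=S(=O)(NCCCCNCc1ccc(Br)cc1)c1cc(C(F)(F)F)cc(C(F)(F)F)c1` gives 1700 nM in a functional assay on BXPC-3 cells (Homo sapiens) for inhibition, read by MTT assay, with a stated time of 72 h; a higher number here means a weaker inhibitor of growth, a lower number a stronger inhibitor of growth. Compound 2 `O=S(=O)(NCCCNCC1COc2ccccc2O1)c1cc(C(F)(F)F)cc(C(F)(F)F)c1` gives 1200 nM in this assay. The two numbers sit within the usual scatter of each other, so neither compound can be called the stronger inhibitor on this evidence.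

Compound 3 `O=S(=O)(NCCCNCc1ccc(Br)cc1)c1cc(C(F)(F)F)cc(C(F)(F)F)c1` is the next compound to be tested. It keeps the core and the three-carbon linker of compound 2 and changes only the group on the far end of the amine: 4-bromophenyl in place of 2,3-dihydro-1,4-benzodioxin-2-yl on a saturated chain carbon bound to an amine nitrogen. Among the compounds with values here, no measured pair shows the effect of this exact change, but compound 1 already carries the same 4-bromobenzyl group on a chain one carbon longer, and its number is close to that of compound 2.

Compound 3 is therefore expected to land near both measured compounds, and the step of a 1.3-fold higher number from compound 2 to compound 3 (0.10 log units; within the scatter) is expected to stay within the scatter rather than move in a clear direction. The estimate for compound 3 in this assay is 1500 nM, with a plausible range from 600 nM to 4000 nM.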

Compound 3, concentration for 50% growth inhibition: 1500 nM
Beside the measured number, compound 3's estimate shows no gap at the digits printed; the measured number falls inside the stated range.
By their numbers in this assay, from the lowest: compounds 2, 3 and 1 (each within the scatter of the next).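

Within the data shown here, this is the first direct reading of this position, and in this assay the 4-bromophenyl group in place of 2,3-dihydro-1,4-benzodioxin-2-yl on a saturated chain carbon bound to an amine nitrogen gives a 1.3-fold higher number from compound 2 to compound 3 (0.10 log units; within the scatter), so this swap of a two-ring group for a single aromatic ring cannot be told apart from no effect. Among these compounds, it also gives the first direct reading of chain length: with the 4-bromobenzyl group kept, shortening the chain gives a 1.1-fold lower number from compound 1 to compound 3 (0.05 log units; within the scatter), so this change, too, cannot be read as a gain or a loss in growth inhibition. No measurement is available that would explain either result.

The compounds shown leave open whether a very different group on the amine arm, such as a carboxylic acid or a morpholine, or a longer chain, would carry the number beyond the scatter. They also leave open whether replacing the trifluoromethyl groups on the shared core with nitrile groups would matter more than either of these changes to the amine arm.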